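Sulfonamide amine swap on the pancreatic cell series

A few compounds are considered here, and "the series" means these few. Any claim that something is new, unique, unknown or untested is made for them only; others in the source may bear on it.

In a functional assay on MIA PaCa-2 cells (Homo sapiens) for inhibition, read by MTT assay, with a stated time of 7 days (on this read-out lower numbers stand for stronger inhibition and higher numbers for weaker inhibition), compound 1 `CCOC(=O)[C@@H]1CCCN(S(=O)(=O)c2ccc(S(=O)(=O)N3CCCCC3)cc2)C1` gives 2900 nM. Compound 2 `CC(C)c1noc(N2CCN(C(=O)[C@@H]3CCCN(S(=O)(=O)c4ccc(S(=O)(=O)NC5CC5)cc4)C3)CC2)n1` gives in this assay 1000 nM, the lowest of the two numbers shown, with compound 1 standing higher by more than the scatter. Compound 3 `CCN(CC)S(=O)(=O)c1ccc(S(=O)(=O)N2CCC[C@@H](C(=O)N3CCN(c4nc(C(C)C)no4)CC3)C2)cc1` differs from compound 2 in one place: diethylamino in place of cyclopropylamino on a sulfonyl sulfur. For the measured compounds named here, no measured pair shares this change, so the step has no anchor. Compound 3 is expected to give about 1500 nM in this assay, within 500 nM to 4500 nM. The step of a 1.5-fold higher number from compound 2 to compound 3 (0.18 log units; within the scatter) is expected to be small, likely within the scatter or a slight weakening.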

Compound 3, half-maximal inhibitory concentration: 50 nM
Compound 3: the middle estimate sits 30-fold (1.48 log units) above what was measured; measured number below the stated range.
By their numbers in this assay, from the lowest: compound 3; then compound 2; then compound 1.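

In this assay this position on a sulfonyl sulfur proves highly sensitive to its amine: diethylamino in place of cyclopropylamino gives a 20-fold lower number from compound 2 to compound 3 (1.30 log units; beyond the scatter) with the rest of the structure unchanged. The swap removes the three-membered ring and the hydrogen-bond donor together, and this single pair cannot separate the two.

On these data alone, whether dimethylamino or pyrrolidine on the same sulfur would keep this level remains open. Nothing shown gives a cause for the step.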